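The source may report more compounds than this note shows. Statements on the series, on what has been measured and on what is new or still open speak of the compounds shown alone.

Measured set in a functional assay on MCF7 cells (Homo sapiens) for cytotoxicity, read by MTT assay, with a stated time of 72 h; a lower number here means a stronger inhibitor, a higher number a weaker inhibitor:
compound 1 `CCC(C)=C1C(=O)N(c2ccc(Cl)cc2)N(c2ccc(Cl)cc2)C1=O` gives 41600 nM
compound 2 `O=C1C(=Cc2ccc(O)cc2)C(=O)N(c2ccc(Cl)cc2)N1c1ccc(Cl)cc1` gives 23200 nM
compound 3 `COc1cccc(C=C2C(=O)N(c3ccc(Cl)cc3)N(c3ccc(Cl)cc3)C2=O)c1O` gives 26700 nM

Compound 3 holds the second highest of the three numbers; compound 2 is nearest and compound 1 furthest, yet both gaps fall within the scatter, so no order among the three can be read from them. The step to compound 4 `O=C1C(=Cc2ccccc2)C(=O)N(c2ccc(Cl)cc2)N1c1ccc(Cl)cc1` alters only the ring on the double-bonded chain carbon bound to a double-bonded ring carbon: phenyl in place of 2-hydroxy-3-methoxyphenyl on a double-bonded chain carbon bound to a double-bonded ring carbon. Within the data shown here, the single measured step that bears on such a swap of that ring is a 1.2-fold higher number from compound 2 to compound 3 (0.06 log units; within the scatter), which stayed within the scatter. A further change at the same ring is therefore expected to leave this assay essentially unchanged, with no step beyond the scatter. The expected step is a 1.0-fold higher number from compound 3 to compound 4 (0.02 log units; within the scatter). Compound 4 is accordingly estimated at 28000 nM, within 12000 nM to 65000 nM.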

Compound 4, half-maximal inhibitory concentration: 20200 nM
Estimate against measurement, compound 4: 1.4-fold (0.14 log units) above; measured number inside the range.
By their numbers in this assay, from the lowest: compounds 4, 2, 3 and 1 (each within the scatter of the next, the first and the last beyond it).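

In this assay phenyl in place of 2-hydroxy-3-methoxyphenyl gives a 1.3-fold lower number from compound 3 to compound 4 (0.12 log units; within the scatter) and hydrogen in place of hydroxy on an aromatic carbon gives a 1.1-fold lower number from compound 2 to compound 4 (0.06 log units; within the scatter) with neither step beyond the scatter. The ring without any substituent therefore reads level with both substituted rings, so neither hydroxy nor methoxy is needed to hold this number. Nothing at hand bears on the cause of this flat result.

On these data alone, whether an amine or a carboxylic acid on this ring, or a longer chain in its place, would move the number beyond the scatter stays open.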